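The source may report more compounds than this note shows. Statements on the series, on what has been measured and on what is new or still open speak of the compounds shown alone.

Measured so far:
Compound 1 `Cc1ccc(S(=O)(=O)NCc2ccc(CNC(=O)c3ccc([N+](=O)[O-])cc3)cc2)cc1`: in an assay on MDA-MB-231 cells for binding affinity to C-X-C chemokine receptor type 4 (Homo sapiens), read by immunofluorescence and microscopy, with stated times of 10 min and 30 min (on this read-out lower numbers stand for an effect already at smaller amounts and higher numbers for an effect only at larger amounts of compound), compound 1 gives 10 nM.
Compound 2 `O=C(NCc1ccc(CNS(=O)(=O)c2ccccc2)cc1)c1cccnc1`: in this assay compound 2 gives 10 nM.

Compound 1 stands level with compound 2 at the digits shown; the two readings lie within the usual scatter, so no order between them can be claimed. Compound 3 `Cc1ccc(S(=O)(=O)NCc2ccc(CNC(=O)c3cccc(Cl)c3)cc2)cc1` has not yet been measured. It differs from compound 1 at one place: 3-chlorophenyl in place of 4-nitrophenyl on a carbonyl carbon. With two measured compounds at the same reading, the change at this carbonyl carbon is expected to move the number little. The step of a 1.5-fold higher number from compound 1 to compound 3 (0.18 log units; within the scatter) is expected to fall within the scatter or to be only slightly weakening. For compound 3 the estimate is 15 nM, expected between 5 nM and 60 nM.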

Compound 3, effective concentration (reported as EC, without a stated level of effect): 100 nM
Compound 3: middle estimate off by 6.7-fold (0.82 log units), on the low side, outside the stated range (above it).
By their numbers in this assay, from the lowest: compounds 1 and 2 (each within the scatter of the next); then compound 3.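

In this assay, this carbonyl carbon proves sensitive to what it carries: 3-chlorophenyl in place of 4-nitrophenyl gives a 10-fold higher number from compound 1 to compound 3 (1.00 log units; beyond the scatter), a step beyond the scatter. Before this, no pair differing in one place existed, so nothing showed whether this position responds to change at all. Nothing measured here accounts for the step. The swap alters both the ring's substituent and its location, and 4-chlorophenyl would help separate the two. As far as these compounds go, how a plain phenyl or an aminophenyl would read also remains open.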